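Sulfonyl in place of ketone on a shared chromanol core

This account rests on a few compounds, and the source may have more. Where it says the series, first, only, none or still open, it means among the compounds named here.

Three compounds have been measured in a functional assay (aorta) with Rattus norvegicus as the target; a lower number here means a stronger inhibitor, a higher number a weaker inhibitor:

compound 1, `CC1(C)Oc2ccc(C(=O)c3ccccc3)cc2[C@@H](/N=C(\NC#N)Nc2ccc(Cl)cc2)[C@@H]1O`: 7100 nM
compound 2, `CC1(C)Oc2ccc(C(=O)Cc3ccccc3)cc2[C@@H](/N=C(\NC#N)Nc2ccc(Cl)cc2)[C@@H]1O`: 6800 nM
compound 3, `CC1(C)Oc2ccc(S(=O)(=O)N3CCCCC3)cc2[C@@H](/N=C(\NC#N)Nc2ccc(Cl)cc2)[C@@H]1O`: 1900 nM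

Compound 2 holds the second highest of the three numbers; its nearest neighbour is compound 1, with a 1.0-fold lower number from compound 1 to compound 2 (0.02 log units; within the scatter), and its furthest is compound 3. Compound 4, `CC1(C)Oc2ccc(S(=O)(=O)NC3CCCCC3)cc2[C@@H](/N=C(\NC#N)Nc2ccc(Cl)cc2)[C@@H]1O`, differs from compound 2 in one place: cyclohexylsulfamoyl in place of benzylcarbonyl on an aromatic carbon. The step that bears most directly on this change is the one with a 3.6-fold lower number from compound 2 to compound 3 (0.55 log units; beyond the scatter), where a sulfonyl-linked ring likewise replaced the benzylcarbonyl; the parallel step with a 3.7-fold lower number from compound 1 to compound 3 (0.57 log units; beyond the scatter) was of the same size. A modest step downward is therefore expected for compound 4, a 3.0-fold lower number from compound 2 to compound 4 (0.47 log units; beyond the scatter). Compound 4 is estimated at 2300 nM, within a range of 900 nM to 6000 nM.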

Compound 4, half-maximal inhibitory concentration: 11700 nM
Estimate against measurement, compound 4: 5.1-fold (0.71 log units) below, outside the stated range (above it).
By their numbers in this assay, from the lowest: compound 3; then compounds 2, 1 and 4 (each within the scatter of the next).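

In this assay the sulfonyl link alone does not carry the gain at this aromatic carbon: cyclohexylamino in place of piperidin-1-yl on the sulfonyl sulfur gives a 6.2-fold higher number from compound 3 to compound 4 (0.79 log units; beyond the scatter) and so cancels it. Against the two ketones, cyclohexylsulfamoyl gives a 1.7-fold higher number from compound 2 to compound 4 (0.24 log units; within the scatter) and a 1.6-fold higher number from compound 1 to compound 4 (0.22 log units; within the scatter) and thus no separation from either. The group on the sulfur, not the sulfonyl alone, therefore decides the result here.

Going by these compounds, whether a morpholine or a dimethylamino group on the sulfur would follow compound 3 or compound 4 stays open. No measured evidence accounts for the gap between these two compounds.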